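Azetidin-1-yl in place of pyrrolidin-1-yl: working notes

This account rests on a few compounds, and the source may have more. Where it says the series, first, only, none or still open, it means among the compounds named here.

Read-out: a functional assay on MCF7 cells (Homo sapiens) for inhibition, read by sulforhodamine B assay; on this read-out higher numbers stand for weaker inhibition and lower numbers for stronger inhibition
compound 1 `CCc1ccc(NC2=CC(=O)c3c(nc4n3[C@H]3OC[C@@H](O)[C@H]3OC4)C2=O)cc1` gives 8990 nM
compound 2 `O=C1C(N2CCCC2)=CC(=O)c2c1nc1n2[C@H]2OC[C@@H](O)[C@H]2OC1` gives > 16000 nM as a limit

Compound 2 stands on the limit of > 16000 nM in this assay, at which 1 of the 2 values shown sits, and has no number. Compound 3 `O=C1C(N2CCC2)=CC(=O)c2c1nc1n2[C@H]2OC[C@@H](O)[C@H]2OC1` is not yet measured and differs from compound 2 by azetidin-1-yl in place of pyrrolidin-1-yl on a double-bonded ring carbon on a double-bonded ring carbon. Among the measured compounds shown here, one measured step bears on this place: an at least 1.7-fold higher number from compound 1 to compound 2 (0.25 log units; that floor lies within the scatter) and it swaps a different group. The expected step is a step that the limit leaves unreadable from compound 2 to compound 3 and so no change beyond the scatter is expected in this assay from this swap. Compound 3 is estimated at 18000 nM within an expected range of 8000 nM to 40000 nM in these notes.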

Compound 3, half-maximal inhibitory concentration: > 16000 nM
Compound 3 gave a limit, no number; the forecaster's own chance of this, stated with the estimate: 60%; the middle value lies beyond the limit too.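

In this assay compound 3 also gives a limit rather than a number, so shrinking the ring from five-membered to four-membered yields no readable value, and the step between the two ring groups cannot be read. Azetidin-1-yl in place of (4-ethylphenyl)amino gives an at least 1.7-fold higher number from compound 1 to compound 3 (0.25 log units; that floor lies within the scatter), which shows no more than the pyrrolidin-1-yl swap did. The two ring groups rest on the same assay limit: the limit of > 16000 nM in this assay, at which 2 of the 3 values shown sit.

Going by these compounds, how far either compound lies past that limit remains open. So does whether a morpholin-4-yl group or a plain benzylamino group at this double-bonded ring carbon would return a number.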